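Swapping an ethyl for a phenyl on compound 3's nitrogen chain

This account rests on a few compounds, and the source may have more. Where it says the series, first, only, none or still open, it means among the compounds named here.

Of the compounds shown here, three have numbers so far. In a functional assay (brain) for displacement of a labelled ligand, with Rattus norvegicus as the target (on this read-out lower numbers stand for stronger inhibition and higher numbers for weaker inhibition), compound 1 `CC(C)[C@]1(c2ccccc2)OC[C@H]([C@@H]2CCCCN2)O1` gives 45 nM and compound 2 `CC[C@]1(c2cccc(N=C=S)c2)OC[C@H]([C@@H]2CCCCN2)O1` gives 590 nM. Compound 3 `CCCN1CCCC[C@H]1[C@H]1COC(c2ccccc2)(c2ccccc2)O1` gives 6800 nM in this assay, the highest number of the three: a higher number than compound 2 and a still higher number than compound 1, both gaps beyond the scatter. Compound 4 `c1ccc(CN2CCCC[C@H]2[C@H]2COC(c3ccccc3)(c3ccccc3)O2)cc1` differs from compound 3 in one place: phenyl in place of ethyl on a saturated chain carbon bound to an amine nitrogen in a ring, so that the propyl becomes a benzyl. Within the data shown here, no measured pair shows what such a change does, so the expected step from compound 3 to compound 4 a 1.4-fold lower number from compound 3 to compound 4 (0.13 log units; within the scatter) is small, in either direction, and not clearly beyond the scatter. Compound 4 is therefore estimated at 5000 nM, within 1500 nM to 20000 nM.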

Compound 4, inhibition constant: 10100 nM
Estimate against measurement, compound 4: 2.0-fold (0.31 log units) below; low and high end bracket the measured number.
By their numbers in this assay, from the lowest: compound 1; then compound 2; then compounds 3 and 4 (each within the scatter of the next).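

In this assay, phenyl in place of ethyl on a saturated chain carbon bound to an amine nitrogen in a ring gives a 1.5-fold higher number from compound 3 to compound 4 (0.17 log units; within the scatter) and so does not separate the two compounds. At this position, then, a group of six heavy atoms with an aromatic ring reads the same as one of two heavy atoms with no ring. No measurement shown here offers a reason for this result. Still open, from the compounds shown here alone, is whether a longer chain, such as phenethyl, or a chain ending in an amine or a carboxylic acid, would also leave the number within the scatter.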